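Carbamoyl in Place of Acetamido on a Weak Inhibitor

A few compounds are considered here, and "the series" means these few. Any claim that something is new, unique, unknown or untested is made for them only; others in the source may bear on it.

compound 1 `CC(=O)Nc1ccc(-c2nnc(C3(c4ccc(Cl)cc4)CCC3)n2C)c(Cl)c1`: > 4000 nM
compound 2 `Cn1c(-c2ccc(-c3cnccn3)cc2F)nnc1C1(c2ccc(Cl)cc2)CCC1`: > 4000 nM

In an assay on isolated protein for inhibition of 11-beta-hydroxysteroid dehydrogenase type 2 (Homo sapiens) (on this read-out lower numbers stand for stronger inhibition and higher numbers for weaker inhibition), compound 1 gives only a limit, > 4000 nM. Compound 2 likewise returns only a limit, > 4000 nM. Both readings sit at the limit of > 4000 nM in this assay, at which 2 of the 2 values shown sit, so compound 1 stands at the edge of what this assay resolves, and nothing measured separates it from compound 2. Compound 3 `Cn1c(-c2ccc(C(N)=O)cc2Cl)nnc1C1(c2ccc(Cl)cc2)CCC1` differs from compound 1 by carbamoyl in place of acetamido on an aromatic carbon. Within the data shown here, no measured step of this kind exists, so no shift beyond the scatter is expected, and compound 3 is expected to stay at the limit. Its estimated value is 8000 nM, within 3000 nM to 30000 nM, which is expected to mean a step that the limit leaves unreadable from compound 1 to compound 3.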

Compound 3, half-maximal inhibitory concentration: > 4000 nM
Compound 3: no number, only a limit (the forecaster's own chance of this, stated with the estimate: 80%); the middle value lies beyond the limit too.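

In this assay, among these compounds, compound 1 and compound 3 both give only a limit, and no step between them can be read: the limit of > 4000 nM in this assay, at which 3 of the 3 values shown sit.
The compounds shown leave open how strongly each inhibits, and whether carbamoyl in place of acetamido changes that at all.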